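Series notes: amino for bromo, compound 3 to compound 4

The source may report more compounds than this note shows. Statements on the series, on what has been measured and on what is new or still open speak of the compounds shown alone.

Measured in a functional assay on MCF7 cells (Homo sapiens) for cytotoxicity, read by MTT assay, with a stated time of 48 h; on this read-out lower numbers stand for stronger inhibition and higher numbers for weaker inhibition:
compound 1 `Fc1cccc(Nc2nc(-c3cccc(F)c3)nc3ccc(F)cc23)c1` gives 48700 nM.
compound 2 `Fc1cccc(-c2nc(Nc3ccc(Br)cc3)c3cc(F)ccc3n2)c1` gives > 50000 nM, a limit of the assay.
compound 3 `Fc1cccc(-c2nc(Nc3ccccc3Br)c3cc(F)ccc3n2)c1` gives > 50000 nM, a limit of the assay.

Only compound 1 returns a number in this assay; the other two stop at the limit of > 50000 nM in this assay, at which 2 of the 3 values shown sit. The steps that follow from this are an at least 1.0-fold higher number from compound 1 to compound 2 (0.01 log units; that floor lies within the scatter) and an at least 1.0-fold higher number from compound 1 to compound 3 (0.01 log units; that floor lies within the scatter), both set by the limit, and a step that the two limits leave unreadable from compound 2 to compound 3, which cannot be read at all. Compound 3 therefore stands at the upper edge of what this assay reports, with no number of its own.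

Compound 4 `Nc1ccccc1Nc1nc(-c2cccc(F)c2)nc2ccc(F)cc12` differs from compound 3 by amino in place of bromo on an aromatic carbon. Among the compounds with values here, none of the measured steps touches this position: they exchange the whole aryl on the nitrogen, and two of them end at the limit. Within the data shown here, no measured step therefore bears directly on the change to compound 4, and the expected step is none beyond the scatter, so that compound 4 is estimated to move by an at least 1.1-fold lower number from compound 3 to compound 4 (0.04 log units; that floor lies within the scatter).

For compound 4 the estimate in this assay is 45000 nM, with a range from 12000 nM to 60000 nM, and the result is expected most often to come back as a limit again.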

Compound 4, half-maximal inhibitory concentration: > 50000 nM
Compound 4: a limit, no number; the forecaster's own chance of this, stated with the estimate: 60%; middle value at least 1.1-fold (0.04 log units) from the limit.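

In this assay compound 4 gives > 50000 nM, which is a limit of the assay and not a number. Amino in place of bromo on this aromatic carbon, ortho to a large group, brings in a hydrogen-bond donor and still gives no readable value, so this position now joins the exchanges of the whole aryl on the nitrogen in ending at the same edge of the read-out: the limit of > 50000 nM in this assay, at which 3 of the 4 values shown sit. The one step that can be stated is an at least 1.0-fold higher number from compound 1 to compound 4 (0.01 log units; that floor lies within the scatter), and the steps among compound 2, compound 3 and compound 4 cannot be read, as each has a limit at both ends.

From the compounds shown here alone, how far compound 2, compound 3 and compound 4 lie past the limit stays open, and with it whether amino and bromo at this position differ at all. Also open, going by these compounds, is whether a hydroxyl group or a carboxylic acid on the same aromatic carbon would return a number in this assay.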